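The source may hold more compounds than are shown below. What is called first, only, known or untested is meant among the compounds shown, and "the series" means these compounds.

Measured in a functional assay on SW-620 cells (Homo sapiens) for antiproliferative activity, read by MTT assay, with a stated time of 24 h; a higher number here means a weaker inhibitor, a lower number a stronger inhibitor:
- Compound 1 `COc1ccc(C(=O)/C=C/c2ccc(N(C)C)cc2)c2c1C=CC(C)(C)O2`: 570 nM.
- Compound 2 `COc1ccc(C(=O)/C=C/c2ccccc2)c2c1C=CC(C)(C)O2`: > 10000 nM, which is a limit and not a number.
- Compound 3 `COc1ccc(C(=O)/C=C/c2ccccn2)c2c1C=CC(C)(C)O2`: 5000 nM.

Compound 3 holds the higher of the two true numbers. The gap to the other is an 8.8-fold higher number from compound 1 to compound 3 (0.94 log units; beyond the scatter).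

Compound 4 `COc1ccc(C(=O)/C=C/c2ccc(Cl)c(Cl)c2)c2c1C=CC(C)(C)O2` is not yet measured. The change to it is 3,4-dichlorophenyl in place of pyridin-2-yl on a double-bonded chain carbon bound to a double-bonded chain carbon.

Within the data shown here, three measured steps bear on this, all from changes to the same aryl group. The largest is an at least 17-fold higher number from compound 1 to compound 2 (1.24 log units; beyond the scatter). The closest comparison is an at least 2.0-fold lower number from compound 2 to compound 3 (0.30 log units; that floor lies within the scatter), and it sets only a floor. Among the measured compounds shown here, no measured compound carries the 3,4-dichlorophenyl group, so these steps fix neither size nor direction firmly.

Taking compound 3 at 5000 nM as the starting point, no change beyond the scatter is expected, and the estimate is a 1.3-fold lower number from compound 3 to compound 4 (0.10 log units; within the scatter). Compound 4 is expected at 4000 nM, with an estimated range of 1000 nM to 10000 nM.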

Compound 4, half-maximal inhibitory concentration: 7700 nM
Compound 4: the middle estimate sits 1.9-fold (0.28 log units) below what was measured; measured number inside the range.
By their numbers in this assay, from the lowest: compound 1; then compounds 3 and 4 (each within the scatter of the next). At a limit, above all of these: compound 2.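

Putting 3,4-dichlorophenyl in place of pyridin-2-yl on a double-bonded chain carbon bound to a double-bonded chain carbon gives a 1.5-fold higher number from compound 3 to compound 4 (0.19 log units; within the scatter). The same position still separates compound 4 from compound 1, a 14-fold higher number from compound 1 to compound 4 (1.13 log units; beyond the scatter), so among compounds 1, 3 and 4, only the 4-(dimethylamino)phenyl group of compound 1 stands apart, while a chlorinated carbon ring and a pyridine ring cannot be told apart here. Compound 2 stands at a limit, which is not a number: the limit of > 10000 nM in this assay, at which 1 of the 4 values shown sits. With 3,4-dichlorophenyl in place of phenyl on the same carbon, only a floor can be given: an at least 1.2-fold lower number from compound 2 to compound 4 (0.11 log units; that floor lies within the scatter).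

Going by these compounds, it remains open whether the lower number of compound 1 is specific to dimethylamino or also holds for a primary amine, a morpholine or a methoxy group on the same ring. On these data alone, the effect of a single chlorine on the phenyl ring is also open.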